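The source may report more compounds than this note shows. Statements on the series, on what has been measured and on what is new or still open speak of the compounds shown alone.

Measured so far in an ADME assay on L02 cells (Homo sapiens) for antiproliferative activity, read by CCK-8 assay, with a stated time of 6 days; on this read-out lower numbers stand for stronger inhibition and higher numbers for weaker inhibition:
compound 1 `CCN(c1ccc(C#N)c(Cl)c1)c1cc(-c2ccccc2)ccc1C`: > 30000 nM
compound 2 `CCN(c1cccc(-c2ccccc2)c1)c1ccc(C#N)c(Cl)c1`: "not determined" (no result reported)
compound 3 `Cc1noc(C)c1-c1cccc2c1CCCN2c1ccc(C#N)c(C(F)(F)F)c1`: "not determined" (no result reported)

Compound 1 stands at the limit of > 30000 nM in this assay, at which 1 of the 3 values shown sits, and this value is a limit of the assay rather than a number. Compound 2 and compound 3 contribute no figure, so a single measured entry is all that the assay holds for this series. Compound 4 `CCN(c1ccc(C#N)c(Cl)c1)c1cc(-c2c[nH]nc2C)ccc1C` differs from compound 1 by one change: 3-methyl-1H-pyrazol-4-yl in place of phenyl on an aromatic carbon. For the measured compounds named here, no measured step between two compounds exists here, so nothing shows how such a swap moves the read-out; the expectation is a step in this assay within the usual scatter, in no particular direction. Compound 4 is therefore expected to land near 30000 nM, with a range from 10000 nM to 90000 nM, and may again be reported only as a limit. The expected step is a number no higher from compound 1 to compound 4 (the limit leaves the size open).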

Compound 4, half-maximal inhibitory concentration: 5780 nM
Compound 4: the middle estimate sits 5.2-fold (0.72 log units) above what was measured; measured number below the stated range.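

In this assay, 3-methyl-1H-pyrazol-4-yl in place of phenyl gives an at least 5.1-fold lower number from compound 1 to compound 4 (0.71 log units; beyond the scatter), which shows that the read-out responds to the group carried at this aromatic carbon. The step has no fixed size, since compound 1 gives only a limit of the assay: the limit of > 30000 nM in this assay, at which 1 of the 4 values shown sits.

The compounds shown leave open whether the methyl group or the two ring nitrogens account for the step. They also do not tell how an amine or a carboxylic acid at this position would read.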